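From a Protected Acyl Chain to a Methyl Group

A few compounds are considered here, and "the series" means these few. Any claim that something is new, unique, unknown or untested is made for them only; others in the source may bear on it.

Compound 1 `COc1ccc(C2=C(c3ccc(SC)cc3)CC3CCCN3C2=O)cc1OC(=O)CNC(=O)OC(C)(C)C` carries a protected acyl chain on an oxygen on an aromatic ring. In a functional assay on SW-620 cells (Homo sapiens) for cytotoxicity (a lower number here means a stronger inhibitor of growth, a higher number a weaker inhibitor of growth), compound 1 gives 20000 nM, and compound 2 `COc1ccc(C2=C(c3ccc(SC)cc3)CC3CCCN3C2=O)cc1OC(=O)C1CCCN1C(=O)OC(C)(C)C` gives 10000 nM. Among the measured compounds shown here, the two stand together at the high end of the numbers so far. Compound 3 `CSc1ccc(C2=C(c3ccc(F)c(F)c3)C(=O)N3CCCC3C2)cc1` has no such chain and also differs from compound 1 elsewhere. Compound 3 gives 200 nM, far below both.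

Compound 4 `COc1ccc(C2=C(c3ccc(SC)cc3)CC3CCCN3C2=O)cc1OC` keeps the core of compound 1 but has methyl in place of (((tert-butoxycarbonyl)amino)methyl)carbonyl on an oxygen on an aromatic ring. For the measured compounds named here, the only measured step, a 2.0-fold lower number from compound 1 to compound 2 (0.30 log units; within the scatter), exchanges one protected acyl group for another and stays within the scatter. Going by the values given here, it therefore says little about removing the chain altogether, and no measured pair isolates that change. The expectation of a lower number in this assay rests instead on compound 3 at 200 nM, an indirect guide given its other differences. The step is expected to be a 10-fold lower number from compound 1 to compound 4 (1.00 log units; beyond the scatter). Its size is uncertain. Compound 4 is estimated at 2000 nM, with an expected range from 300 nM to 12000 nM.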

Compound 4, concentration for 50% growth inhibition: 3000 nM
Beside the measured number, compound 4's estimate is 1.5-fold (0.18 log units) below it; measured number inside the range.
By their numbers in this assay, from the lowest: compound 3; then compound 4; then compounds 2 and 1 (each within the scatter of the next).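

Among the compounds shown here, the step of a 6.7-fold lower number from compound 1 to compound 4 (0.82 log units; beyond the scatter) is the first measured change that removes the (((tert-butoxycarbonyl)amino)methyl)carbonyl group rather than exchanging it for another protected acyl group. It shows that, with the core of compound 1 held fixed, the group on this oxygen on an aromatic ring can change the number in this assay beyond the scatter, whereas the earlier step of a 2.0-fold lower number from compound 1 to compound 2 (0.30 log units; within the scatter) left that open. Here a chain of 11 heavy atoms, with its hydrogen-bond donor and three acceptors, gives way to a single methyl, but nothing given here explains the shift.

This single pair cannot separate the effect of losing the carbamate-bearing chain from any contribution of the methyl itself, and compound 4 is only one point on this oxygen. A free hydroxyl group, an ethyl group or longer alkyl chain, or an acyl chain ending in a free amine would show whether the number tracks the length of the chain, the acyl link or the protecting group.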